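Hydroxy on the compound 3 core: cytotoxicity working notes

This account rests on a few compounds, and the source may have more. Where it says the series, first, only, none or still open, it means among the compounds named here.

Measured in a functional assay on MT4 cells (Homo sapiens), read by MTT assay; a higher number here means that more compound is tolerated, a lower number that less compound is tolerated:
- compound 1 `C#C[C@]1(CO)O[C@@H](n2cc(C)c(=O)[nH]c2=O)C[C@@H]1O`: > 380000 nM (a limit)
- compound 2 `C#C[C@]1(CO)O[C@@H](n2cnc3c(N)ncnc32)C[C@@H]1O`: 11700 nM
- compound 3 `C#C[C@]1(CO)O[C@@H](n2cnc3cncnc32)C[C@@H]1O`: > 380000 nM (a limit)

Compound 3 stands at > 380000 nM, which is a limit of the assay and not a number. The same ceiling applies to more than one compound here: the limit of > 380000 nM in this assay, at which 2 of the 3 values shown sit. Its true position is therefore unknown, and any step away from it can be judged only roughly.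

The next compound is compound 4 `C#C[C@]1(CO)O[C@@H](n2cnc3c(O)ncnc32)C[C@@H]1O`, which has hydroxy in place of hydrogen on an aromatic carbon.

Among the measured compounds shown here, one measured step bears on this change. Going from an amino group to hydrogen on an aromatic carbon gave an at least 32-fold higher number from compound 2 to compound 3 (1.51 log units; beyond the scatter), a large change. Read in reverse, that step shows that a group on this carbon can bring the number down, but the group there was amino and not hydroxy. A fall as large as that one is therefore not assumed, and a small downward move or none beyond the scatter is more likely. The expected change is an at least 1.5-fold lower number from compound 3 to compound 4 (0.18 log units; that floor lies within the scatter). Compound 4 is estimated at 250000 nM, with an expected range from 60000 nM to 400000 nM, and it may well be reported only as a limit.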

Compound 4, half-maximal cytotoxic concentration: 216000 nM
Compound 4: the middle estimate sits 1.2-fold (0.06 log units) above what was measured, and the stated range covers the measured number.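

In this assay, replacing amino with hydroxy on the same aromatic carbon gives an 18-fold higher number from compound 2 to compound 4 (1.27 log units; beyond the scatter), so among the groups shown at this position, the much lower number of compound 2 goes with amino and does not extend to hydroxy. Against hydrogen, hydroxy gives an at least 1.7-fold lower number from compound 3 to compound 4 (0.24 log units; that floor lies within the scatter); this is only a floor that lies within the scatter, so it shows no clear separation of hydroxy from hydrogen, although compound 4 does supply a true number at this position. Compound 3 remains a limit at > 380000 nM, and the step from it cannot be sized more closely because of the shared ceiling: the limit of > 380000 nM in this assay, at which 2 of the 4 values shown sit.

As far as these compounds go, whether the fall in the number needs an amino group itself remains open, and methylamino, dimethylamino, methoxy or chlorine on this carbon would help to separate amino from other substituents. From the compounds shown here alone, it is also open whether hydroxy in place of hydrogen would give a similar step on a core other than that of compound 3.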